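From a tert-butyl to a 4-chlorophenyl oxalamide

A few compounds are considered here, and "the series" means these few. Any claim that something is new, unique, unknown or untested is made for them only; others in the source may bear on it.

Of the compounds shown here, three built on one shared core have been tested in a functional assay on cells (T-cell, Mus musculus) for inhibition; on this read-out higher numbers stand for weaker inhibition and lower numbers for stronger inhibition. Compound 1 `COc1ccccc1/C=C/C(=O)Nc1ccc2c(c1)COC2=O` gives 39 nM. Compound 2 `O=C(Nc1ccc2c(c1)COC2=O)NC1CCCCC1` gives 12700 nM in this assay. Compound 3 `CC(C)(C)NC(=O)C(=O)Nc1ccc2c(c1)COC2=O` gives 3400 nM in this assay, the second highest of the three numbers: its nearest neighbour is compound 2, whose number is higher by a margin beyond the usual scatter, and its furthest is compound 1, whose number is far lower, also beyond the scatter.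

Compound 4 `O=C(Nc1ccc(Cl)cc1)C(=O)Nc1ccc2c(c1)COC2=O` has not yet been measured. It differs from compound 3 in one place: 4-chlorophenyl in place of tert-butyl on an amide-type nitrogen. Going by the values given here, no pair of measured compounds shows exactly this kind of change, so its size cannot be read off directly. Among the three measured compounds, only compound 1 carries an aromatic ring, and it gives the lowest number. On that slender basis compound 4 is expected to inhibit more strongly than compound 3, with the step of a 4.9-fold lower number from compound 3 to compound 4 (0.69 log units; beyond the scatter) expected to lie beyond the scatter, though with much uncertainty. The estimate for compound 4 in this assay is 700 nM, with a range from 120 nM to 4000 nM.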

Compound 4, half-maximal inhibitory concentration: 2240 nM
Compound 4: the middle estimate sits 3.2-fold (0.51 log units) below what was measured; low and high end bracket the measured number.
By their numbers in this assay, from the lowest: compound 1; then compounds 4 and 3 (each within the scatter of the next); then compound 2.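

In this assay, placing 4-chlorophenyl instead of tert-butyl on this amide-type nitrogen gives a 1.5-fold lower number from compound 3 to compound 4 (0.18 log units; within the scatter), so the two groups cannot be told apart here, even though one is an aromatic ring and the other is not. For this pair, then, an aromatic ring at this position does not by itself produce a change larger than the ordinary variation between repeated measurements. No supporting measurement is available to explain why these two different groups give such similar readings. The compounds shown leave open whether plain phenyl would read like 4-chlorophenyl, and so what part, if any, the chlorine plays. They also leave open whether a quite different group on this nitrogen, such as a chain ending in an amine or a carboxylic acid, would shift the number beyond the scatter.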